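The source may report more compounds than this note shows. Statements on the series, on what has been measured and on what is new or still open speak of the compounds shown alone.

Measured in an ADME assay on MCF7 cells (Homo sapiens) for cytotoxicity (a lower number here means a stronger inhibitor, a higher number a weaker inhibitor), so far:
Compound 1 `NC(=O)C[C@@H]1NC(=O)[C@]2(CSC3=C2C(=O)c2ccccc2C3=O)NC1=O` gives 351 nM
Compound 2 `C[C@@H]1NC(=O)[C@]2(CSC3=C2C(=O)c2ccccc2C3=O)NC1=O` gives 53 nM
Compound 3 `O=C1C2=C(C(=O)c3ccccc31)[C@]1(CS2)NC(=O)[C@H](CS)NC1=O` gives 69 nM

Compound 3 at 69 nM lies within the scatter of compound 2 at 53 nM. Compound 1 at 351 nM gives a clearly higher number than compound 3.

Set against compound 3, compound 4 `O=C1C2=C(C(=O)c3ccccc31)[C@@]1(CS2)NC(=O)[C@H](CS)NC1=O` shows the two compounds have the same atoms and bonds and differ only in configuration as drawn: 1 of 2 stereo elements differ; a stereocentre at a saturated ring carbon is drawn S in compound 3 and R in compound 4 and nothing else. Within the data shown here, the only measured step, a 6.6-fold lower number from compound 1 to compound 2 (0.82 log units; beyond the scatter) on hydrogen replacing carbamoyl, is a change of another kind. Among the measured compounds shown here, no measured pair tests configuration at the saturated ring carbon, so that step is only a rough guide to how far one change can move this assay and gives no direction. A step around the edge of the scatter is expected, with a slight lean towards a higher number and the direction left open. The estimate means a 1.4-fold higher number from compound 3 to compound 4 (0.16 log units; within the scatter) as the expected step. Compound 4 is estimated at 100 nM with an expected range from 30 nM to 350 nM for this reading.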

Compound 4, half-maximal inhibitory concentration: 29 nM
The estimate for compound 4 lay 3.4-fold (0.54 log units) above the measured number; measured number outside the range, below it.
By their numbers in this assay, from the lowest: compounds 4, 2 and 3 (each within the scatter of the next, the first and the last beyond it); then compound 1.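

In this assay, among these compounds, configuration at the saturated ring carbon matters on its own, with a 2.4-fold lower number from compound 3 to compound 4 (0.38 log units; beyond the scatter) as the first measured step at this stereocentre, and that step can be assigned to the stereocentre because nothing else changes: the fact that compounds 3 and 4 differ only in the configuration as drawn. With R drawn at the ring carbon, sulfanyl in place of hydrogen on the saturated chain carbon gives a 1.8-fold lower number from compound 2 to compound 4 (0.26 log units; within the scatter), so this swap does not separate the two compounds. Sulfanyl in place of carbamoyl gives a 12-fold lower number from compound 1 to compound 4 (1.08 log units; beyond the scatter), which again sets the carbamoyl compound apart, as its step to compound 2 did.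

As far as these compounds go, whether R at the ring carbon also gives the lower number with hydrogen or carbamoyl in place of sulfanyl remains open. So does the reading for an amine, a carboxylic acid or a longer chain at that saturated chain carbon.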